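The source may report more compounds than this note shows. Statements on the series, on what has been measured and on what is new or still open speak of the compounds shown alone.

Measured so far:
compound 1, `Cc1noc(NS(=O)(=O)c2cccc([N+](=O)[O-])c2)c1C`: 7800 nM
compound 2, `Cc1noc(NS(=O)(=O)c2cccc3c(N4CCCCC4=O)cccc23)c1C`: 270 nM

Both numbers come from an assay on VSM-A10 cells for antagonist activity at Endothelin-1 receptor (Rattus norvegicus); a higher number here means a weaker inhibitor, a lower number a stronger inhibitor. Compound 2 holds the lower of the two half-maximal inhibitory concentrations; compound 1 sits a long way up, beyond the scatter, so compound 2 is the stronger inhibitor of the pair. For the measured compounds named here, no two measured compounds differ in a single place, so there is no measured step to lean on.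

Compound 3, `Cc1noc(NS(=O)(=O)c2cccc3c(N4CCCC4=O)cccc23)c1C`, has not yet been measured. It differs from compound 2 in one place: 2-oxopyrrolidin-1-yl in place of 2-oxopiperidin-1-yl on an aromatic carbon. Going by the values given here, nothing among the measured compounds speaks to this change. Given the one-atom difference, the expected step in this assay is none beyond the scatter, or at most a slight rise in the number. Compound 3 is therefore estimated at 350 nM, with a range of 120 nM to 1000 nM. The step this estimate implies, a 1.3-fold higher number from compound 2 to compound 3 (0.11 log units; within the scatter), is expected to stay within the usual scatter.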

Compound 3, half-maximal inhibitory concentration: 130 nM
Compound 3: middle estimate off by 2.7-fold (0.43 log units), on the high side, and the stated range covers the measured number.
By their numbers in this assay, from the lowest: compound 3; then compound 2; then compound 1.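

In this assay, for the compounds shown here, 2-oxopyrrolidin-1-yl in place of 2-oxopiperidin-1-yl on this aromatic carbon gives a 2.1-fold lower number from compound 2 to compound 3 (0.32 log units; beyond the scatter), the first single-place step. The position therefore registers a change of ring size alone, with the five-membered ring the stronger of the two, even though the hydrogen-bond donor and acceptor counts stay the same and the carbonyl is kept. Nothing available explains why the smaller ring gives the lower number.

From the compounds shown here alone, two ring sizes fix no trend, so it remains open whether a four-membered azetidin-2-one would continue in the same direction. Also open, going by these compounds, is whether a ring is needed here at all, which an open-chain acetamide or a plain amine on the same aromatic carbon would address.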